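A few compounds are considered here, and "the series" means these few. Any claim that something is new, unique, unknown or untested is made for them only; others in the source may bear on it.

Compound 1 `CCCCOC(=O)NS(=O)(=O)c1ccc(CCC)cc1-c1ccc(Cn2c(C(C)C)nc3ccccc32)cc1` gives 4 nM in an assay on membranes from HEK293 cells for displacement of a labelled ligand from Type-2 angiotensin II receptor (Homo sapiens), read by radioligand binding; on this read-out higher numbers stand for weaker inhibition and lower numbers for stronger inhibition.
Compound 2 `CCCCOC(=O)NS(=O)(=O)c1ccc(CCC)cc1-c1ccc(Cn2c(C3CC3)nc3ccccc32)cc1` gives 31 nM in this assay.

For the measured compounds named here, compound 2 holds the higher of the two numbers, and the only measured step leading to it, a 7.8-fold higher number from compound 1 to compound 2 (0.89 log units; beyond the scatter), lies beyond the scatter. Compound 3 `CCCCOC(=O)NS(=O)(=O)c1ccc(CCC)cc1-c1ccc(Cn2c(C(F)(F)F)nc3ccccc32)cc1` differs from compound 2 in a single place: trifluoromethyl in place of cyclopropyl on an aromatic carbon. Going by the values given here, no measured pair exchanges a cyclopropyl for a trifluoromethyl, so no step bears directly on this change; the step from compound 1 to compound 2 shows only that swapping the group at this aromatic carbon between two ring nitrogen atoms can move the number by a modest amount in either direction. With no closer guide, the number for compound 3 is expected to stay near that of compound 2, with a wide range. This corresponds to an expected 1.0-fold lower number from compound 2 to compound 3 (0.01 log units; within the scatter). Compound 3 is estimated to give 30 nM in this assay, between 6 nM and 150 nM.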

Compound 3, inhibition constant: 13 nM
Estimate against measurement, compound 3: 2.3-fold (0.36 log units) above; the measured number falls inside the stated range.
By their numbers in this assay, from the lowest: compound 1; then compound 3; then compound 2.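

Replacing the cyclopropyl ring with trifluoromethyl, a group with no ring and three fluorine atoms, brings a 2.4-fold lower number from compound 2 to compound 3 (0.38 log units; beyond the scatter) in this assay and so a modest gain in inhibition. Trifluoromethyl still trails isopropyl, as a 3.3-fold higher number from compound 1 to compound 3 (0.51 log units; beyond the scatter) shows, which places the three groups at this carbon between two ring nitrogen atoms in a clear order: isopropyl gives the strongest inhibition, trifluoromethyl comes next and cyclopropyl gives the weakest. No evidence is available on what sets this order.

These three groups leave open whether any other group at this carbon can match isopropyl, such as a tert-butyl group, an ethyl group, a longer chain or an amine. They also leave open whether the same order would hold with a different group in place of the propyl chain.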